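Chloro for methylsulfanyl: working notes on the series

The source may hold more compounds than are shown below. What is called first, only, known or untested is meant among the compounds shown, and "the series" means these compounds.

Values in a functional assay on L1210 cells (Mus musculus) for inhibition; on this read-out higher numbers stand for weaker inhibition and lower numbers for stronger inhibition:
- compound 1 `C#CCN(Cc1ccc2nc(S)nc(O)c2c1)c1ccc(C(=O)NC(CCC(=O)O)C(=O)O)cc1`: 60000 nM
- compound 2 `C#CCN(Cc1ccc2nc(SC)nc(O)c2c1)c1ccc(C(=O)NC(CCC(=O)O)C(=O)O)cc1`: 13000 nM

Going by the values given here, compound 2 holds the lower of the two numbers so far. Compound 3 `C#CCN(Cc1ccc2nc(Cl)nc(O)c2c1)c1ccc(C(=O)NC(CCC(=O)O)C(=O)O)cc1` has chloro in place of methylsulfanyl on an aromatic carbon, between two ring nitrogen atoms (chloro in place of methylsulfanyl on an aromatic carbon). Among the compounds with values here, one measured step bears on this change: methyl in place of hydrogen on a sulfur, a modest step beyond the scatter (a 4.6-fold lower number from compound 1 to compound 2 (0.66 log units; beyond the scatter)). Chloro was not among the groups tested, so the data do not fix a direction. A step no larger than that one is expected in this assay, probably within the scatter. The expected step is small (a 1.3-fold lower number from compound 2 to compound 3 (0.11 log units; within the scatter)). For compound 3 the estimated value is 10000 nM (range 3000 nM to 40000 nM).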

Compound 3, half-maximal inhibitory concentration: 67000 nM
Beside the measured number, compound 3's estimate is 6.7-fold (0.83 log units) below it, outside the stated range (above it).
By their numbers in this assay, from the lowest: compound 2; then compounds 1 and 3 (each within the scatter of the next).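

In this assay chloro in place of methylsulfanyl on this carbon between two ring nitrogen atoms gives a 5.2-fold higher number from compound 2 to compound 3 (0.71 log units; beyond the scatter) and so does not keep the lower number of compound 2. Chloro in place of sulfanyl gives a 1.1-fold higher number from compound 1 to compound 3 (0.05 log units; within the scatter) and so leaves these two groups inseparable here, with methylsulfanyl alone standing apart among the three. Nothing available accounts for this difference. As far as these compounds go, whether the lower number of compound 2 depends on the sulfur or on its methyl stays open, as does the outcome with methoxy, amino or ethylsulfanyl on this carbon.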